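Changing One Ring Beside the Acid

A few compounds are considered here, and "the series" means these few. Any claim that something is new, unique, unknown or untested is made for them only; others in the source may bear on it.

Compound 1, `Cc1ccc(CC(Oc2ccc(C(C)C)cc2)C(=O)O)cc1`, gives in a functional assay on the whole organism for inhibition, with Rattus norvegicus as the target (a lower number here means that less compound is needed, a higher number that more compound is needed for the effect), a value of < 50 mg/kg, which is a limit of the assay rather than a number.
Compound 2, `Cc1ccc(CC(C)(Oc2ccc(C(C)C)cc2)C(=O)O)cc1`, gives in this assay a value of < 1 mg/kg, again a limit and not a number.

Compound 2 therefore stands at the limit of < 1 mg/kg in this assay, at which 1 of the 2 values shown sits, and nothing tighter is known about it. Going by the values given here, the one measured step, a step that the two limits leave unreadable from compound 1 to compound 2, cannot be sized, since both of its ends are limits. Compound 3, `CC(C)c1ccc(OC(C)(Cc2ccc(Cl)c(Cl)c2)C(=O)O)cc1`, differs from compound 2 in a single place: 3,4-dichlorophenyl in place of 4-methylphenyl on a saturated chain carbon, two bonds along the chain from a carbonyl carbon and an oxygen on an aromatic ring. No measured step touches this ring, so nothing shown bears on the change, and no shift beyond the usual scatter can be argued in either direction. The expectation for compound 3 in this assay is therefore anchored only on the limit of compound 2, and compound 3 is estimated at 1 mg/kg with a range from 0.2 mg/kg to 5 mg/kg. That estimate means an expected step of a number no lower from compound 2 to compound 3 (the limit leaves the size open), which is not a real prediction of change but a placeholder for an unknown.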

Compound 3, dose for half-maximal effect: 5 mg/kg
Compound 3: middle estimate off by 5.0-fold (0.70 log units), on the low side, within the range that was stated.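

On the saturated chain carbon, two bonds along the chain from a carbonyl carbon and an oxygen on an aromatic ring, putting 3,4-dichlorophenyl in place of 4-methylphenyl gives in this assay an at least 5.0-fold higher number from compound 2 to compound 3 (0.69 log units; beyond the scatter), so this ring is not a silent part of the molecule: more compound is needed after the change. That size is only a minimum because compound 2 carries a limit of the assay and not a number: the limit of < 1 mg/kg in this assay, at which 1 of the 3 values shown sits.

Compound 3, at 5 mg/kg, also holds the first true number among the compounds shown, a fixed point for sizing further changes in this ring. The step from compound 1 to compound 2 still cannot be read, since both of its ends are limits.

The swap removes a methyl and adds two chlorines in one move, so nothing shown tells whether the shift follows from the lost methyl, from one chlorine or from the other, and no measured property accounts for it. A 4-chlorophenyl or a plain phenyl at this place would begin to pull these apart.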